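The compounds below may be only part of what the source reports. "The series", "measured", "known", "first", "only" and "open" are said of these compounds alone.

Compound 2 `CCOC(=O)C1=C(C)NC(=S)NC1c1ccc(SC)cc1` gives 35.7 ug/mL in a functional assay on NCI/ADR-RES cells (Homo sapiens) for inhibition, read by sulforhodamine B assay, with a stated time of 48 h (a lower number here means a stronger inhibitor of growth, a higher number a weaker inhibitor of growth), and stands highest of the two numbers; compound 1 `CCOC(=O)C1=C(C)NC(=O)NC1c1ccc(O)cc1` gives 3.2 ug/mL, a lower value, and the gap between the two lies well beyond the usual scatter. Compound 3 `CCOC(=O)C1=C(C)NC(=S)NC1c1ccc(F)cc1` differs from compound 2 in one place: fluoro in place of methylsulfanyl on an aromatic carbon. For the measured compounds named here, no measured pair shows this change, so compound 3 is expected to stay near compound 2, with a step of a 1.2-fold lower number from compound 2 to compound 3 (0.08 log units; within the scatter) that is not expected to exceed the scatter. Compound 3 is therefore estimated at 30 ug/mL, within a range from 10 ug/mL to 90 ug/mL.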

Compound 3, concentration for 50% growth inhibition: 26.1 ug/mL
For compound 3 the middle estimate is 1.1-fold (0.06 log units) above the measured one; the range from low to high includes it.
By their numbers in this assay, from the lowest: compound 1; then compounds 3 and 2 (each within the scatter of the next).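

In this assay, for the compounds shown here, fluoro in place of methylsulfanyl on an aromatic carbon gives a 1.4-fold lower number from compound 2 to compound 3 (0.14 log units; within the scatter), the first direct reading of a single change at this position. At this position on the shared core, the two groups cannot be told apart by this read-out. No available evidence bears on the reason for this.

As far as these compounds go, it remains open whether an amine, a carboxylic acid or a longer chain at this position would give a step beyond the scatter. From the compounds shown here alone, compound 1 differs from compound 2 and compound 3 in more than one place, so the contribution of each of its differences also remains open.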